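A few compounds are considered here, and "the series" means these few. Any claim that something is new, unique, unknown or untested is made for them only; others in the source may bear on it.

For the measured compounds named here, compound 2 `COC(=O)c1sc2cc(C#Cc3ccccc3N)cnc2c1N` is the only member of this small set with a numerical result: in a functional assay on MCF7 cells (Homo sapiens) for inhibition, read by sulforhodamine B assay, with a stated time of 48 h (a lower number here means a stronger inhibitor of growth, a higher number a weaker inhibitor of growth), compound 2 gives 4100 nM. Its closest relative, compound 1 `COC(=O)c1sc2cc(C#Cc3ccccc3OC)cnc2c1N`, is not placed by a number. In this assay compound 1 reaches only > 47300 nM, which is a limit of the assay rather than a measured value (the limit of > 47300 nM in this assay, at which 1 of the 2 values shown sits). Going by the values given here, the one measured step, an at least 11-fold lower number from compound 1 to compound 2 (1.06 log units; beyond the scatter), therefore shows that the aryl substituent on the alkyne matters greatly here, the amino-bearing ring being the one that yields a readable number.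

Compound 3 `COC(=O)c1sc2cc(C#Cc3ccc(F)cc3)cnc2c1N` moves away from that amino-bearing ring: 4-fluorophenyl in place of 2-aminophenyl on a triple-bonded carbon. The change removes the hydrogen-bond donor that distinguishes compound 2 from compound 1 and, with it, the group that went with the large gain in that step. Among the compounds with values here, the only step available points in the unfavourable direction for such a removal, so a clear rise in the number is expected in this assay, possibly back to the region where only a limit is reported. Compound 3 is thus estimated at 25000 nM, within 6000 nM to 80000 nM, which corresponds to an expected step of a 6.1-fold higher number from compound 2 to compound 3 (0.79 log units; beyond the scatter).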

Compound 3, concentration for 50% growth inhibition: 29000 nM
Estimate against measurement, compound 3: 1.2-fold (0.06 log units) below, and the stated range covers the measured number.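

Compound 1 had left open whether any ring on this triple-bonded carbon other than 2-aminophenyl could give a readable number in this assay; 4-fluorophenyl does, although the cost of losing 2-aminophenyl is still clear: a 7.1-fold higher number from compound 2 to compound 3 (0.85 log units; beyond the scatter). Set against 2-methoxyphenyl, the same ring gives an at least 1.6-fold lower number from compound 1 to compound 3 (0.21 log units; that floor lies within the scatter), and since that floor lies within the scatter, this pair does not establish any real separation between 4-fluorophenyl and 2-methoxyphenyl. Compound 1 remains a limit of the assay and not a number, so the true distance of that step stays unknown: the limit of > 47300 nM in this assay, at which 1 of the 3 values shown sits.

The 2-aminophenyl and 4-fluorophenyl rings differ both in the group they carry and in where it sits, so the compounds shown cannot tell whether the lower number of compound 2 goes with the amino group itself or with its place on the ring. A 4-aminophenyl ring and a 2-fluorophenyl ring would separate those two readings, and a 2-hydroxyphenyl ring or a 2-(dimethylamino)phenyl ring would ask whether another group in the same place can match the amine.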